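Swapping a hydroxy-methoxy chain for an isoprenyl group

The source may report more compounds than this note shows. Statements on the series, on what has been measured and on what is new or still open speak of the compounds shown alone.

Compound 1 `C=CC(C)(C)c1[nH]c2ccc(C[C@H](O)C(C)(C)OC)cc2c1/C=C1\NC(=O)[C@H](C)NC1=O`: in an ADME assay on MDCK cells (Canis lupus familiaris) for cytotoxicity, read by CellTiter-Glo, with a stated time of 40 h (on this read-out higher numbers stand for lower toxicity in this test and lower numbers for higher toxicity in this test), compound 1 gives only a limit, > 200000 nM.
Compound 2 `C=CC(C)(C)c1[nH]c2ccc(C[C@H](O)C(C)(C)OC)cc2c1/C=c1\[nH]c(=O)c(=C)[nH]c1=O`: in this assay compound 2 likewise gives only a limit, > 200000 nM.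

Both measured compounds sit at the same limit, so the step that the two limits leave unreadable from compound 1 to compound 2 cannot be read; the limit of > 200000 nM in this assay, at which 2 of the 2 values shown sit, shows this. Compound 3 `C=CC(C)(C)c1[nH]c2ccc(CC=C(C)C)cc2c1/C=c1\[nH]c(=O)c(=C)[nH]c1=O` is not yet measured. It differs from compound 2 by 2-methylprop-1-en-1-yl in place of 1-hydroxy-2-methoxy-2-methylpropyl on a saturated chain carbon bound to an aromatic carbon. Going by the values given here, no measured step bears on this change, and compound 2 stands at the limit, so no step beyond the scatter is foreseen. Compound 3 is expected to give about 200000 nM, between 50000 nM and 600000 nM, an estimated step of a number no higher from compound 2 to compound 3 (the limit leaves the size open).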

Compound 3, half-maximal cytotoxic concentration: > 200000 nM
Compound 3: only a limit was reported (the forecaster's own chance of this, stated with the estimate: 75%); the middle value lies on the limit itself.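

Going by these compounds alone, for compound 2 and compound 3, each result is only a limit, so no step between them can be read: the limit of > 200000 nM in this assay, at which 3 of the 3 values shown sit.
How far this change of chain moves the result in this assay stays open, as every compound shown gives only a limit.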